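The source may hold more compounds than are shown below. What is called first, only, known or untested is meant among the compounds shown, and "the series" means these compounds.

Two compounds of the series carry a number. Compound 1 `COc1ccc(Cc2nc(N)c3nn(-c4ccccc4)cc3n2)cc1` gives 38% in an assay on CHO cells for displacement of a labelled ligand from adenosine receptor A3 (Homo sapiens), read by scintillation counting, tested at 1 uM; a higher number here means more inhibition at the concentration tested (going by the name of the read-out), a lower number less inhibition. Going by the values given here, compound 2 `Cc1cccc(Cc2nc(N)c3nn(-c4ccccc4)cc3n2)c1` gives 11% in this assay, so compound 2 stands lowest of the two numbers, with compound 1 as its only neighbour; the single measured step, a number 27 percentage points lower from compound 1 to compound 2 (beyond the scatter), is the one that ends at compound 2. Among the compounds with values here, compound 3 `Nc1nc(Cc2cccc(C(F)(F)F)c2)nc2cn(-c3ccccc3)nc12` has not yet been measured. trifluoromethyl in place of methyl on an aromatic carbon No measured step exchanges methyl for trifluoromethyl, so nothing bears directly on this change; the one step on record swapped one whole aryl group for another and was modest. Without direct precedent, a step of a number 7 percentage points higher from compound 2 to compound 3 (within the scatter) is expected, lying within the scatter or barely beyond it, with the direction open. For compound 3 the estimate in this assay is 18%, within a range of 4% to 40%.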

Compound 3, a percentage reported as inhibition, at one concentration (the size of the read-out at that concentration, not a potency): 41%
Beside the measured number, compound 3's estimate is 23 percentage points below it, and the stated range ends below it.
By their numbers in this assay, from the lowest: compound 2; then compounds 1 and 3 (each within the scatter of the next).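

Trifluoromethyl in place of methyl on an aromatic carbon, meta to a large group, gives a number 30 percentage points higher from compound 2 to compound 3 (beyond the scatter) in this assay and is a larger move than the scatter allows. The earlier step exchanged a whole aryl group, whereas this one shows that changing a single group at this place, with the rest of compound 2 held constant, is enough to shift the read-out. No measurement on hand accounts for the size or direction of this step.

From the compounds shown here alone, it remains open whether other groups at this place, such as chlorine, a nitrile, a methoxy group or an amine, would read like methyl or like trifluoromethyl. Also open, going by these compounds, is whether trifluoromethyl would give a similar step on another carbon of the same ring, or with a different group on the shared core.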